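Removing the Chloro Group from the Phenoxy Ring

A few compounds are considered here, and "the series" means these few. Any claim that something is new, unique, unknown or untested is made for them only; others in the source may bear on it.

Of the compounds shown here, three have so far been measured in a physicochemical assay for solubility, with a stated time of 18 h, at pH 7.4; a lower number here means a less soluble compound, a higher number a more soluble compound. Compound 1 `COc1cccc(CNCCCNc2ccnc3cc(Oc4ccc(Cl)cc4)ccc23)c1O` gives 14500 nM in this assay, which places it second highest among the three numbers. Its nearest neighbour is compound 2 `Fc1ccc(-c2ccc3c(NCCCNCc4ccco4)ccnc3c2)cc1`, which gives 32000 nM in this assay, a higher number than compound 1 by more than the usual scatter. The furthest is compound 3 `COc1ccc(F)cc1CNCCCNc1ccnc2cc(CC(C)C)ccc12`, which gives 4200 nM in this assay, lower than compound 1 by more than the scatter. Within the data shown here, no two of these measured compounds differ in a single place, so no measured step is available as a direct guide.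

Compound 4 `COc1cccc(CNCCCNc2ccnc3cc(Oc4ccccc4)ccc23)c1O` differs from compound 1 in one place: hydrogen in place of chloro on an aromatic carbon. Among the measured compounds shown here, with no measured step of this kind to rest on, the change is expected to shift the number upward by a modest amount, close to the edge of the scatter. The step expected is a 1.7-fold higher number from compound 1 to compound 4 (0.24 log units; within the scatter). Compound 4 is accordingly estimated at 25000 nM in this assay, with a range from 10000 nM to 60000 nM.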

Compound 4, solubility: 14500 nM
Compound 4: middle estimate off by 1.7-fold (0.24 log units), on the high side, and the stated range covers the measured number.
By their numbers in this assay, from the lowest: compound 3; then compounds 1 and 4 (each within the scatter of the next); then compound 2.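

In this assay, among these compounds, the step from 4-chlorophenoxy to phenoxy gives the first direct reading at this position, with no change at the digits printed from compound 1 to compound 4 (within the scatter) for hydrogen in place of chloro on an aromatic carbon. The earlier compounds shown here differ from one another in more than one place, whereas this pair isolates a single change and shows that the chlorine atom can leave this ring without a readable shift in the number. Nothing measured here bears on why the number holds.

The compounds shown leave open whether a different group at this position, such as a methoxy group, an amine or a carboxylic acid, would move the number beyond the scatter. They also leave open whether the same exchange of chloro for hydrogen would read the same way with a different amine side chain on the shared core.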